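Sulfonamide series: aryl amide to directly bound aryl

A few compounds are considered here, and "the series" means these few. Any claim that something is new, unique, unknown or untested is made for them only; others in the source may bear on it.

Two compounds have numbers in an assay on isolated protein for inhibition of alkaline phosphatase, tissue-nonspecific isozyme (Homo sapiens); on this read-out lower numbers stand for stronger inhibition and higher numbers for weaker inhibition. Compound 1 `COc1ccc(OC)c(S(=O)(=O)Nc2cncc(-c3ccncc3)c2)c1` gives 73 nM. Compound 2 `COc1ccc(Cl)cc1S(=O)(=O)Nc1cncc(C(=O)Nc2ccccc2)c1` gives 310 nM, the higher of the two numbers, and the gap to compound 1 is beyond the usual scatter. Compound 3 `COc1ccc(Cl)cc1S(=O)(=O)Nc1cncc(-c2ccccc2C)c1` is not yet measured; it differs from compound 2 in one place: 2-methylphenyl in place of phenylcarbamoyl on an aromatic carbon. Among the compounds with values here, no pair of measured compounds shows this exact change. Compound 1 carries a directly bound aromatic ring at this position and gives the lower number, so a step in the direction of a lower number, clearly beyond the scatter, is expected from compound 2 to compound 3, namely a 2.8-fold lower number from compound 2 to compound 3 (0.45 log units; beyond the scatter). Compound 3 is estimated at 110 nM, with a range from 35 nM to 350 nM.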

Compound 3, half-maximal inhibitory concentration: 178 nM
The estimate for compound 3 lay 1.6-fold (0.21 log units) below the measured number; measured number inside the range.
By their numbers in this assay, from the lowest: compound 1; then compounds 3 and 2 (each within the scatter of the next).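

In this assay, 2-methylphenyl in place of phenylcarbamoyl gives a 1.7-fold lower number from compound 2 to compound 3 (0.24 log units; within the scatter). This position therefore tolerates losing the carbonyl and the amide hydrogen: the entering group has no hydrogen-bond donors or acceptors, yet the number stays within the scatter of compound 2. No supporting evidence is available to explain this result.

Going by these compounds, whether a plain phenyl or a carboxylic acid at this position would read differently remains open. Compound 1 differs from compound 3 in more than one place, so the two cannot be compared directly.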